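Urea series: bicyclic amine changes at the carbamoyl nitrogen

A few compounds are considered here, and "the series" means these few. Any claim that something is new, unique, unknown or untested is made for them only; others in the source may bear on it.

Measured compounds:
compound 1 `O=C(Nc1noc2ccccc12)N1CCN(Cc2cccc(Oc3ccc(Cl)cc3)c2)CC1`, 8.1 nM
compound 2 `O=C(Nc1noc2ccncc12)N1CCN(Cc2cccc(Oc3ccc(Cl)cc3)c2)CC1`, 2200 nM

In an assay on isolated protein for inhibition of Fatty-acid amide hydrolase 1 (Rattus norvegicus), with a stated time of 60 min (a higher number here means a weaker inhibitor, a lower number a stronger inhibitor), compound 2 stands highest of the two numbers shown; the nearest is compound 1, and the single step is a 270-fold higher number from compound 1 to compound 2 (2.43 log units; beyond the scatter), a large loss. Compound 3 `O=C(Nc1ccc2nccn2c1)N1CCN(Cc2cccc(Oc3ccc(Cl)cc3)c2)CC1` has not been measured. It differs from compound 2 by a group of 9 heavy atoms (7 carbon, 2 nitrogen; one five-membered aromatic ring with 2 hetero atoms, one six-membered aromatic ring with 1 hetero atom) in place of a group of 9 heavy atoms (6 carbon, 2 nitrogen, 1 oxygen; one five-membered aromatic ring with 2 hetero atoms, one six-membered aromatic ring with 1 hetero atom), on an amide-type nitrogen. Going by the values given here, the only measured step, a 270-fold higher number from compound 1 to compound 2 (2.43 log units; beyond the scatter), shows that exchanging the bicyclic group on the carbamoyl nitrogen can move the number by a large amount, but it does not tell in which direction a further exchange of this kind will go. With no closer comparison, the number for compound 3 is expected near that of compound 2, with a wide range covering both a recovery toward compound 1 and a further loss. Compound 3 is therefore estimated at 1500 nM, range 150 nM to 15000 nM, a step of a 1.5-fold lower number from compound 2 to compound 3 (0.17 log units; within the scatter) that is expected to lie within the scatter.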

Compound 3, half-maximal inhibitory concentration: 3600 nM
For compound 3 the middle estimate is 2.4-fold (0.38 log units) below the measured one; low and high end bracket the measured number.
By their numbers in this assay, from the lowest: compound 1; then compounds 2 and 3 (each within the scatter of the next).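

In this assay, replacing the group on the amide-type nitrogen of compound 2 with one that has no oxygen and one hetero atom fewer among its acceptors gives no readable separation (a 1.6-fold higher number from compound 2 to compound 3 (0.21 log units; within the scatter)), so these two bicyclic groups cannot be told apart at this position. Compound 1 remains clearly apart from this second group as well (a 440-fold higher number from compound 1 to compound 3 (2.65 log units; beyond the scatter)); among the three compounds, both groups with a hetero atom in the six-membered aromatic ring give far higher numbers than the group whose six-membered ring is carbon only, and no compound shown goes against this. Nothing available bears on the reason for these steps.

Open, from the compounds shown here alone, is whether a benzimidazolyl group, with a carbon-only six-membered ring and no oxygen, stays near compound 1. Also open, going by these compounds, is whether a single-ring phenyl group at the same nitrogen keeps that number.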